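Methyl for chloro: from compound 1 to compound 3

A few compounds are considered here, and "the series" means these few. Any claim that something is new, unique, unknown or untested is made for them only; others in the source may bear on it.

Measured so far:
compound 1 `Clc1ccc(COc2ccc(OCCOCCNC3CCCC3)cc2)cc1` – 7670 nM
compound 2 `CC(C)(C)OC(=O)n1ccc(NCCOCCOc2ccc(OCc3ccccc3)cc2)c1` – 13000 nM

Two compounds carry numbers in a functional assay on SK-OV-3 cells (Homo sapiens) for inhibition, read by CCK-8 assay, with a stated time of 70 h; a lower number here means a stronger inhibitor, a higher number a weaker inhibitor. Compound 1 `Clc1ccc(COc2ccc(OCCOCCNC3CCCC3)cc2)cc1` gives 7670 nM in this assay, the lower of the two. Compound 2 `CC(C)(C)OC(=O)n1ccc(NCCOCCOc2ccc(OCc3ccccc3)cc2)c1` gives 13000 nM in this assay; the two values sit within the scatter of each other, so no order between them can be read. Within the data shown here, the two structures differ in more than one place and no single-change step connects them.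

Compound 3 `Cc1ccc(COc2ccc(OCCOCCNC3CCCC3)cc2)cc1` has not been measured. It differs from compound 1 by methyl in place of chloro on an aromatic carbon. Among the measured compounds shown here, both groups are single heavy atoms without ring, donor, acceptor or charge, exchanged on the same aromatic carbon; nothing among the measured compounds tells how this assay answers such an exchange.

The step expected from compound 1 to compound 3 is a 1.2-fold higher number from compound 1 to compound 3 (0.07 log units; within the scatter), i.e. nothing clearly beyond the scatter. Compound 3 is expected to give about 9000 nM in this assay, with a range from 3500 nM to 25000 nM, since the anchor is compound 1 at 7670 nM and the change is small.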

Compound 3, half-maximal inhibitory concentration: 17200 nM
Beside the measured number, compound 3's estimate is 1.9-fold (0.28 log units) below it; low and high end bracket the measured number.
By their numbers in this assay, from the lowest: compounds 1, 2 and 3 (each within the scatter of the next, the first and the last beyond it).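

In this assay, among these compounds, methyl in place of chloro on the aromatic carbon para to a large group gives a 2.2-fold higher number from compound 1 to compound 3 (0.35 log units; beyond the scatter), the first single-change step and the first sign that the number responds to what this position carries. The two groups match in what is counted here, each with one heavy atom, no ring, no hydrogen-bond donor or acceptor and no net charge, yet the lower number lies with 4-chlorobenzyl; the step is modest and rests on this one pair. Nothing at hand bears on why the two groups part in this way.

Open, on these data alone, is where fluoro, methoxy or trifluoromethyl would fall at this position relative to chloro and methyl, and whether an amine or a carboxylic acid there would move the number further in either direction. Also open, as far as these compounds go, is whether the chloro-to-methyl step keeps its size when a longer chain replaces the chain at the other end of the core.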